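Phenyl for hydrogen on the core of compound 1

This account rests on a few compounds, and the source may have more. Where it says the series, first, only, none or still open, it means among the compounds named here.

Measured so far in an assay on isolated protein for inhibition of RAC-beta serine/threonine-protein kinase (Homo sapiens), read by mobility shift assay, tested at 30 uM; a lower number here means less inhibition, a higher number more inhibition at the concentration tested (going by the name of the read-out):
compound 1, `Cc1cc2nn(-c3ccccc3)c(N)c2c(=O)[nH]1`, gives 1%
compound 2, `CC(C)(C)c1cc2nn(-c3ccccc3)c(N)c2c(=O)[nH]1`, gives 3%
compound 3, `COc1ccccc1-c1cc2nn(-c3ccccc3)c(N)c2c(=O)[nH]1`, gives 0%

Compound 1 stands second highest of the three, with compound 3 nearest and compound 2 furthest, both within the scatter. Compound 4, `Cc1[nH]c(=O)c2c(N)n(-c3ccccc3)nc2c1-c1ccccc1`, differs from compound 1 by phenyl in place of hydrogen on an aromatic carbon.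

Among the measured compounds shown here, no measured step puts a phenyl on that carbon. The steps that exist change the methyl of compound 1: a number 2 percentage points higher from compound 1 to compound 2 (within the scatter) and a number 1 percentage points lower from compound 1 to compound 3 (within the scatter), with a number 3 percentage points lower from compound 2 to compound 3 (within the scatter) also flat. Each of these groups sits elsewhere, and all leave the read-out near zero, so nothing here argues for a shift beyond the scatter. Compound 4 is therefore expected to stay flat, a number 1 percentage points higher from compound 1 to compound 4 (within the scatter), an estimate of 2% with a range of -5% to 12%.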

Compound 4, a percentage reported as inhibition, at one concentration (the size of the read-out at that concentration, not a potency): 4%
Estimate against measurement, compound 4: 2 percentage points below; the measured number falls inside the stated range.
By their numbers in this assay, from the lowest: compounds 3, 1, 2 and 4 (each within the scatter of the next).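

In this assay the change at this aromatic carbon, ortho to a methyl group, gives a number 3 percentage points higher from compound 1 to compound 4 (within the scatter) and so leaves the read-out near zero. This position, as well as the carbon carrying the methyl of compound 1, has now been changed with no shift beyond the scatter. No available evidence bears on the reason for this flat result.

On these data alone, whether an amine or a carboxylic acid on this carbon would move the read-out remains open. Also open, as far as these compounds go, is whether any group on the shared core can give inhibition clearly beyond the scatter.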